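Swapping the aryl amide for a small aliphatic group

The source may hold more compounds than are shown below. What is called first, only, known or untested is meant among the compounds shown, and "the series" means these compounds.

Measured compounds:
compound 1, `Cc1ccc(C(=O)N[C@@H](C(=O)N2CCC(c3ccc(Cl)cc3)CC2)C(C)C)cc1`: 25 nM
compound 2, `CC(C)[C@@H](NC(=O)c1cc2ccccc2s1)C(=O)N1CCC(c2ccc(Cl)cc2)CC1`: 58 nM

Compound 1 `Cc1ccc(C(=O)N[C@@H](C(=O)N2CCC(c3ccc(Cl)cc3)CC2)C(C)C)cc1` and compound 2 `CC(C)[C@@H](NC(=O)c1cc2ccccc2s1)C(=O)N1CCC(c2ccc(Cl)cc2)CC1` share the same core and differ only in the group on the carbonyl carbon of the amide. In an assay on THP-1 cells for displacement of a labelled ligand from C-C chemokine receptor type 1 (Homo sapiens) (a lower number here means a stronger inhibitor, a higher number a weaker inhibitor), compound 1 gives 25 nM and compound 2 gives 58 nM. Compound 2 therefore holds the higher of the two numbers; its nearest neighbour is compound 1, from which the step is a 2.3-fold higher number from compound 1 to compound 2 (0.37 log units; beyond the scatter).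

Compound 3 `CC(C)[C@@H](NC(=O)CC1CC1)C(=O)N1CCC(c2ccc(Cl)cc2)CC1` is not yet measured. It differs from compound 2 by cyclopropylmethyl in place of 1-benzothiophen-2-yl on a carbonyl carbon. Going by the values given here, both groups in the single measured step were aromatic, so the only guidance is that a change in this position moved the number by a 2.3-fold higher number from compound 1 to compound 2 (0.37 log units; beyond the scatter), and the present change is larger, removing both rings and the acceptor in favour of a small saturated group. A weakening beyond the scatter is therefore expected, with a step of a 5.2-fold higher number from compound 2 to compound 3 (0.71 log units; beyond the scatter). For compound 3 the estimate in this assay is 300 nM, within a range of 80 nM to 1500 nM.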

Compound 3, half-maximal inhibitory concentration: 46 nM
Estimate against measurement, compound 3: 6.5-fold (0.81 log units) above; the measured number lies below the stated range.
By their numbers in this assay, from the lowest: compounds 1, 3 and 2 (each within the scatter of the next, the first and the last beyond it).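

In this assay the aromatic rings on the carbonyl carbon prove not to be required for a number in this range. Cyclopropylmethyl in place of 1-benzothiophen-2-yl gives a 1.3-fold lower number from compound 2 to compound 3 (0.10 log units; within the scatter) even though the entering group has neither of the aromatic rings nor the hydrogen-bond acceptor counted for the leaving group, and cyclopropylmethyl in place of 4-methylphenyl gives a 1.8-fold higher number from compound 1 to compound 3 (0.26 log units; within the scatter) as the other comparison. The earlier step of a 2.3-fold higher number from compound 1 to compound 2 (0.37 log units; beyond the scatter) had shown only that one aromatic group could differ from another, whereas compound 3 now shows that a small saturated group on a carbonyl carbon whose other neighbour is the amide-type nitrogen can stand within the scatter of both aromatic compounds, so it cannot be ranked against either.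

From the compounds shown here alone, it remains open whether this tolerance extends to an amine, a carboxylic acid or a longer chain such as n-butyl on the same carbonyl carbon. The compounds shown come with no measurement that would explain why cyclopropylmethyl is accepted here.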